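A Chlorobenzoyl Swap at the Assay Limit

The compounds below may be only part of what the source reports. "The series", "measured", "known", "first", "only" and "open" are said of these compounds alone.

In a functional assay on SGC-7901 cells (Homo sapiens) for antiproliferative activity, read by MTT assay, with a stated time of 24 h (on this read-out higher numbers stand for weaker inhibition and lower numbers for stronger inhibition), compound 1 (`O=C(NNc1ccccc1F)c1cccc(NS(=O)(=O)c2cnc(O)nc2O)c1`) gives > 20000 nM as a limit, not a number. Compound 2 (`O=C(NNC(=O)c1ccc(NS(=O)(=O)c2cnc(O)nc2O)cc1)c1ccc(F)cc1`) gives > 20000 nM as a limit too. The record so far is therefore the limit of > 20000 nM in this assay, at which 2 of the 2 values shown sit, and holds no exact value. Compound 3 (`O=C(NNC(=O)c1cccc(NS(=O)(=O)c2cnc(O)nc2O)c1)c1cccc(Cl)c1`) differs from compound 1 in one place ((3-chlorophenyl)carbonyl in place of 2-fluorophenyl on an amine nitrogen), with (3-chlorophenyl)carbonyl in place of 2-fluorophenyl on an amine nitrogen. Within the data shown here, no measured step is available as a guide, so in this assay the expected change is a step that the limit leaves unreadable from compound 1 to compound 3 and stays within the scatter, in no particular direction. Compound 3 is estimated at 22000 nM with an expected range from 8000 nM to 40000 nM on this read-out.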

Compound 3, half-maximal inhibitory concentration: 7310 nM
The estimate for compound 3 lay 3.0-fold (0.48 log units) above the measured number; measured number outside the range, below it.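

The change to (3-chlorophenyl)carbonyl in place of 2-fluorophenyl on an amine nitrogen brings an at least 2.7-fold lower number from compound 1 to compound 3 (0.43 log units; beyond the scatter) in this assay, so this place in the molecule can move the read-out, and compound 3 gives the record its first exact value. Compound 1 holds only a limit, so the step has no upper end yet: the limit of > 20000 nM in this assay, at which 2 of the 3 values shown sit.

The carbonyl and the chlorine enter together, and the compounds shown leave open which of them carries the step. Going by these compounds, how an acetyl or a (3-methoxyphenyl)carbonyl would read at this amine nitrogen also remains open.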